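The source may hold more compounds than are shown below. What is called first, only, known or untested is meant among the compounds shown, and "the series" means these compounds.

Measured compounds in a functional assay on HUVEC cells (Homo sapiens), read by fluorescence and microscopy, with a stated time of 6 h, tested at 250 nM; a lower number here means a stronger effect, a higher number a weaker effect of the compound at the concentration tested:
- compound 1 `N#Cc1c(Nc2ccc(N)cc2)sc2ccccc12`, 51%
- compound 2 `COc1cc2sc(Nc3cccc(O)c3)c(C#N)c2cc1OC`, 67%
- compound 3 `N#Cc1c(Nc2ccccc2O)sc2ccccc12`, 68%

Compound 1 stands lowest of the three numbers in this assay, and both of its gaps to the other two compounds lie beyond the usual scatter: compound 2 sits higher, and compound 3 sits a little higher still. Compound 1 therefore shows the strongest effect of the three at the tested concentration. The numbers for compound 2 and compound 3 lie within the scatter of each other, so nothing can be said about their order.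

Compound 4 `N#Cc1c(Nc2ccc(Cl)cc2)sc2ccccc12` has not been measured yet. Its structure differs from compound 1 in one place: chloro in place of amino on an aromatic carbon. Among the compounds with values here, no measured pair in the set isolates this kind of change, so no step can be drawn from the data. Within the data shown here, with only one neighbour of compound 1 altered, and compound 1 already at the low end of the set, a moderate move upward is expected from compound 1 to compound 4, possibly no larger than the scatter, estimated as a number 9 percentage points higher from compound 1 to compound 4 (within the scatter). Compound 4 is accordingly expected to give about 60% in this assay, within a range from 42% to 80%.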

Compound 4, a percentage reported as activity, at one concentration (the size of the read-out at that concentration, not a potency): 45%
For compound 4 the middle estimate is 15 percentage points above the measured one; the range from low to high includes it.
By their numbers in this assay, from the lowest: compounds 4 and 1 (each within the scatter of the next); then compounds 2 and 3 (each within the scatter of the next).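

In this assay, within the data shown here, the one pair in the set that differs in a single place shows that chloro in place of amino on an aromatic carbon, para to a large group, gives a number 6 percentage points lower from compound 1 to compound 4 (within the scatter). The two compounds therefore cannot be told apart at the tested concentration, even though amino carries a hydrogen-bond donor and a hydrogen-bond acceptor and chloro carries neither, so at this place in this series neither is needed to keep the read-out of compound 1. No measurement in hand explains why the two read alike.

Going by these compounds, whether this tolerance extends to other groups at the same place, such as a carboxylic acid, trifluoromethyl or a longer chain, remains open, as does whether chloro would read the same way on the dimethoxy-substituted core of compound 2. On these data alone, with a single concentration in hand, a difference in potency between compound 1 and compound 4 also remains open, since a shared read-out at one concentration need not mean a shared concentration-response curve.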